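Amide to Urea on a Shared Core: Binding Expected Unchanged

This account rests on a few compounds, and the source may have more. Where it says the series, first, only, none or still open, it means among the compounds named here.

Measured so far:
compound 1 `Cc1ccc(C(=O)Nc2nccn3cc(-c4ccccc4)nc23)cc1` — 45%
compound 2 `O=C(Nc1nccn2cc(-c3ccccc3)nc12)c1cccnc1` — 42%

In an assay on cells for displacement of a labelled ligand from transmembrane domain-containing protein TMIGD3 (Homo sapiens), read by scintillation counting, with a stated time of 120 min, tested at 1 uM (a higher number here means more inhibition at the concentration tested (going by the name of the read-out), a lower number less inhibition), compound 1 gives 45%, and compound 2 gives 42%. The one step among these two, a number 3 percentage points lower from compound 1 to compound 2 (within the scatter), came from placing pyridin-3-yl in place of 4-methylphenyl on a carbonyl carbon, and it stays within the scatter. Compound 2 therefore holds the lower of the two numbers, but its neighbour compound 1 sits so close that no order between them can be claimed.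

Compound 3 `O=C(Nc1ccccc1)Nc1nccn2cc(-c3ccccc3)nc12` is the next compound. It differs from compound 2 as follows:

anilino in place of pyridin-3-yl on a carbonyl carbon

Within the data shown here, no measured step touches this kind of change, so the expectation rests only on the observation that the one known change at the same carbonyl carbon, a number 3 percentage points lower from compound 1 to compound 2 (within the scatter), left the read-out essentially where it was. For compound 3 the expected step is a number 2 percentage points lower from compound 2 to compound 3 (within the scatter), none beyond the scatter. Compound 3 is estimated to give 40% in this assay, with a likely range from 20% to 60%.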

Compound 3, a percentage reported as inhibition, at one concentration (the size of the read-out at that concentration, not a potency): 6%
For compound 3 the middle estimate is 34 percentage points above the measured one; measured number below the stated range.
By their numbers in this assay, from the lowest: compound 3; then compounds 2 and 1 (each within the scatter of the next).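

On a carbonyl carbon whose other neighbour is an amide-type nitrogen, anilino gives a number 36 percentage points lower from compound 2 to compound 3 (beyond the scatter) and a number 39 percentage points lower from compound 1 to compound 3 (beyond the scatter) in this assay, so at this place some changes leave the number level and others lower it. Pyridin-3-yl and 4-methylphenyl give numbers within the scatter of each other, whereas anilino, an aromatic ring attached through a nitrogen, gives a much lower number than either. The 4-methylphenyl group of compound 1 is also a six-membered aromatic ring of carbon only, so such a ring alone does not go with the low number, and what compound 3 adds compared with both earlier compounds is the anilino nitrogen and its hydrogen-bond donor. Nothing available here accounts for the size of this drop.

On these data alone, whether the low number goes with the hydrogen on that nitrogen, with the nitrogen itself, or with the particular ring attached to it stays open. An N-methylanilino group, which keeps the nitrogen but replaces its hydrogen with methyl, and a benzyl group, which puts a carbon in place of that nitrogen, would help to separate these possibilities.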